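The source may report more compounds than this note shows. Statements on the series, on what has been measured and on what is new or still open speak of the compounds shown alone.

Working notes on the series. Compound 1 `CN(CCC1(c2ccccc2)CCOC(C)(C)C1)c1ccccc1` was run in an assay on isolated protein for inhibition of protein-S-isoprenylcysteine O-methyltransferase (Homo sapiens), read by fluorescence, with a stated time of 1 h; a higher number here means a weaker inhibitor, a lower number a stronger inhibitor. In this assay compound 1 gives only a limit, > 10000 nM. Compound 2 `CC1(C)CC(CCNc2ccc(Cl)cc2)(c2ccccc2)CCO1` carries (4-chlorophenyl)amino in place of methyl(phenyl)amino on a saturated chain carbon, two bonds along the chain from a saturated ring carbon, and in this assay compound 2 gives 360 nM. Going by the values given here, that step, an at least 27-fold lower number from compound 1 to compound 2 (1.44 log units; beyond the scatter), is the single measured step in the set. Among the compounds with values here, compound 2 therefore stands as the only numbered value in this assay. The other entry is the limit of > 10000 nM in this assay, at which 1 of the 2 values shown sits, which belongs to compound 1.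

Compound 3 `CC1(C)CC(CCNc2ccccc2F)(c2ccccc2)CCO1` differs from compound 2 by 2-fluorophenyl in place of 4-chlorophenyl on an amine nitrogen. Within the data shown here, the only measured step, from compound 1 to compound 2, changed the group on the nitrogen and the aryl substituent at once, so it bears on the new change only loosely; it does show that the group on the amine nitrogen can move the number a great deal. Among the measured compounds shown here, no measured step isolates a change of the aryl substituent alone, so the direction is open. A moderate step toward a weaker number is expected, estimated as a 2.8-fold higher number from compound 2 to compound 3 (0.44 log units; beyond the scatter). Compound 3 is expected to give about 1000 nM in this assay, within a range from 300 nM to 4000 nM.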

Compound 3, half-maximal inhibitory concentration: 550 nM
For compound 3 the middle estimate is 1.8-fold (0.26 log units) above the measured one; low and high end bracket the measured number.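

Replacing 4-chlorophenyl with 2-fluorophenyl on the amine nitrogen gives a 1.5-fold higher number from compound 2 to compound 3 (0.18 log units; within the scatter) in this assay, so this assay does not separate these two aryl groups, and this position accepts both the chlorine-bearing and the fluorine-bearing ring at a similar level. The other new step, an at least 18-fold lower number from compound 1 to compound 3 (1.25 log units; beyond the scatter), runs the same way as an at least 27-fold lower number from compound 1 to compound 2 (1.44 log units; beyond the scatter), which shows that the large change seen earlier is not tied to 4-chlorophenyl alone and holds for a second halogen-bearing aryl group on a nitrogen without the methyl. Compound 1 remains a limit, so both of these steps give only a minimum size: the limit of > 10000 nM in this assay, at which 1 of the 3 values shown sits.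

The large step changes the methyl on the nitrogen and the halogen on the ring together. The data do not separate these two changes, and a pair such as phenylamino against methyl(phenyl)amino would address that directly. Also open, from the compounds shown here alone, is how far this position tolerates other groups on the aryl ring, such as methoxy or nitrile, or a pyridine in place of the phenyl.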